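The source may hold more compounds than are shown below. What is called first, only, known or untested is meant among the compounds shown, and "the series" means these compounds.

Measured in a functional assay on KB cells (Homo sapiens) for inhibition, read by sulforhodamine B assay; a lower number here means a stronger inhibitor of growth, a higher number a weaker inhibitor of growth:
- compound 1 `Fc1ccc(-c2ccc(-c3ccc(-c4nc5ccccc5[nH]4)cc3)cc2)cc1`: 41300 nM
- compound 2 `Oc1ccc(-c2ccc(-c3ccc(-c4nc5ccccc5[nH]4)cc3)cc2)cc1`: 41000 nM

In this assay compound 2 gives 41000 nM and stands level, within the scatter, with compound 1 at 41300 nM. Compound 3 `COc1ccc(-c2ccc(-c3ccc(-c4nc5ccccc5[nH]4)cc3)cc2)cc1` differs from compound 2 by methyl in place of hydrogen on an oxygen on an aromatic ring, so hydroxy becomes methoxy. Within the data shown here, the only measured step, a 1.0-fold lower number from compound 1 to compound 2 (0.00 log units; within the scatter), is hydroxy in place of fluoro on an aromatic carbon and lies within the scatter. Among the measured compounds shown here, no measured step covers this methylation directly, so no shift beyond the scatter is expected. The expected change is a 1.0-fold lower number from compound 2 to compound 3 (0.01 log units; within the scatter). For compound 3 the estimate is 40000 nM, with an expected range of 18000 nM to 80000 nM.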

Compound 3, concentration for 50% growth inhibition: 47200 nM
Beside the measured number, compound 3's estimate is 1.2-fold (0.07 log units) below it, and the stated range covers the measured number.
By their numbers in this assay, from the lowest: compounds 2, 1 and 3 (each within the scatter of the next).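

In this assay, methyl in place of hydrogen on the oxygen gives a 1.2-fold higher number from compound 2 to compound 3 (0.06 log units; within the scatter) and methoxy in place of fluoro gives a 1.1-fold higher number from compound 1 to compound 3 (0.06 log units; within the scatter). Among these compounds, compound 3 therefore stands level with both compound 1 and compound 2, and the methyl on this oxygen, a group the earlier compounds did not carry, leaves the number within the scatter. Fluoro, hydroxy and methoxy on this aromatic carbon cannot be told apart here, and no evidence on the reason is at hand.

From the compounds shown here alone, whether any group at this place moves the number beyond the scatter stays open; an amine, a carboxylic acid or a longer alkoxy chain such as butoxy would test this. Going by these compounds, what the shared core contributes also stays open, since all three compounds carry it unchanged.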